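Chloro to methyl on the sulfonyl arene of compound 3

The compounds below may be only part of what the source reports. "The series", "measured", "known", "first", "only" and "open" are said of these compounds alone.

Three analogues sharing one core have been measured in a functional assay on HCT-116 cells (Homo sapiens) for antiproliferative activity, read by MTT assay, with a stated time of 72 h; on this read-out higher numbers stand for weaker inhibition and lower numbers for stronger inhibition. Compound 1 `COc1c(NS(=O)(=O)c2ccc(F)cc2)cc(-c2ccc3nc(NC(C)=O)sc3c2)cc1C(N)=O` gives 1950 nM. Compound 2 `COc1c(NS(=O)(=O)C2CC2)cc(-c2ccc3nc(NC(C)=O)nn3c2)cc1C(N)=O` gives 36300 nM, and compound 3 `COc1c(NS(=O)(=O)c2ccc(Cl)cc2)cc(-c2ccc3nc(NC(C)=O)nn3c2)cc1C(N)=O` gives 31700 nM. Compound 3 therefore stands second highest of the three numbers; its nearest neighbour is compound 2, its furthest compound 1, which carries a different core and so is not tied to compound 3 by a single change.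

Going by the values given here, the one step that joins two measured compounds, a 1.1-fold lower number from compound 2 to compound 3 (0.06 log units; within the scatter), shows that exchanging the whole group on the sulfonyl sulfur left this assay almost unmoved.

Compound 4 `COc1c(NS(=O)(=O)c2ccc(C)cc2)cc(-c2ccc3nc(NC(C)=O)nn3c2)cc1C(N)=O` differs from compound 3 only by methyl in place of chloro on an aromatic carbon. Among the compounds with values here, no measured pair changes the substituent on that arene, so the only guide is the step from compound 2 to compound 3, which was within the scatter for a larger change at the same sulfonyl position. A step of no more than the scatter is therefore expected, with no direction to favour, as a 1.1-fold lower number from compound 3 to compound 4 (0.02 log units; within the scatter).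

For compound 4 the estimate in this assay is 30000 nM, expected between 10000 nM and 90000 nM.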

Compound 4, half-maximal inhibitory concentration: 27300 nM
Estimate against measurement, compound 4: 1.1-fold (0.04 log units) above, within the range that was stated.
By their numbers in this assay, from the lowest: compound 1; then compounds 4, 3 and 2 (each within the scatter of the next).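

In this assay, the change on the sulfonyl arene itself, methyl in place of chloro, gives a 1.2-fold lower number from compound 3 to compound 4 (0.06 log units; within the scatter), so this exchange of one heavy atom on the arene does not separate compound 3 from compound 4. Going by these compounds alone, the exchange of cyclopropyl for 4-methylphenyl on the sulfonyl sulfur gives a 1.3-fold lower number from compound 2 to compound 4 (0.12 log units; within the scatter), which means that cyclopropyl, 4-chlorophenyl and 4-methylphenyl all lie within the scatter of one another on the shared core, with no pair among compounds 2, 3 and 4 setting one group apart. No measurement is at hand that could account for this flat response.

As far as these compounds go, it remains open whether an amine or a carboxylic acid on the arene, or a longer chain on the sulfonyl sulfur, would shift the number on this core. Compound 1 differs from these three compounds in both its core and its sulfonyl group, so the compounds shown cannot say which of the two parts goes with its separate position in this series.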